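The compounds below may be only part of what the source reports. "The series", "measured", "known", "first", "only" and "open" are said of these compounds alone.

Among the compounds with values here, compound 2 `Cc1ccc(C2C(C#N)=C(N)OC(c3c[nH]c4ccccc34)=C2C#N)cc1` gives 8.5% in a functional assay, tested at 400 ug/mL (on this read-out lower numbers stand for a weaker effect and higher numbers for a stronger effect at the one concentration tested), the lowest of the two numbers measured so far; compound 1 `COc1ccc(C2C(C#N)=C(N)OC(c3c[nH]c4ccccc34)=C2C#N)cc1OC` gives 28.1%. Within the data shown here, the one step on record, a number 19.6 percentage points lower from compound 1 to compound 2 (beyond the scatter), came with 4-methylphenyl in place of 3,4-dimethoxyphenyl on a saturated ring carbon. Compound 3 `COc1ccc(C2C(C#N)=C(N)OC(c3c[nH]c4ccccc34)=C2C#N)cc1` differs from compound 2 by methoxy in place of methyl on an aromatic carbon, a change that moves back toward the substitution pattern of compound 1. Since that single step bears only in part on this change, compound 3 is expected to rise modestly, by a number 9.5 percentage points higher from compound 2 to compound 3 (within the scatter). The estimated value of compound 3 is 18%, ranging from 6% to 32%.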

Compound 3, a percentage reported as activity, at one concentration (the size of the read-out at that concentration, not a potency): 28.7%
Compound 3: the middle estimate sits 10.7 percentage points below what was measured; the range from low to high includes it.
By their numbers in this assay, from the lowest: compound 2; then compounds 1 and 3 (each within the scatter of the next).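

In this assay, methoxy in place of methyl on the aromatic carbon para to a large group gives a number 20.2 percentage points higher from compound 2 to compound 3 (beyond the scatter), so the earlier drop can be placed at this carbon. The second methoxy of compound 1 shows no separate contribution: hydrogen in its place gives a number 0.6 percentage points higher from compound 1 to compound 3 (within the scatter). No evidence is at hand that explains this result. From the compounds shown here alone, what stays open is whether a hydroxyl, an amine or a longer chain such as ethoxy at that carbon would keep the read-out at the level of compound 3.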